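The source may report more compounds than this note shows. Statements on the series, on what has been measured and on what is new or still open speak of the compounds shown alone.

Measured values in a functional assay on PC-3 cells (Homo sapiens) for antiproliferative activity; on this read-out higher numbers stand for weaker inhibition of growth and lower numbers for stronger inhibition of growth:

- compound 1 `COc1ccccc1CN1CC=C(CCC(=O)NO)C1=O`: 3560 nM
- compound 2 `COc1ccccc1CCCN1CC=C(CCC(=O)NO)C1=O`: 3510 nM
- compound 3 `COc1cccc(CCCN2CC=C(CCC(=O)NO)C2=O)c1`: 2590 nM

Compound 1 gives the highest of the three numbers in this assay. Its nearest neighbour is compound 2, whose number is within the scatter of that of compound 1; the furthest is compound 3, and that gap, too, lies within the scatter. No two of these three compounds differ in only one place, so no single-point step can be read from them, and nothing can be said about the weight of any one change on this read-out.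

Compound 4 `O=C(CCC1=CCN(Cc2ccccc2)C1=O)NO` is not yet measured. Relative to compound 1 the change is hydrogen in place of methoxy on an aromatic carbon. Going by the values given here, no comparable step between measured compounds exists, so there is no measured basis for a direction. The step from compound 1 to compound 4 is expected to be small, not clearly beyond the scatter, at a 1.0-fold lower number from compound 1 to compound 4 (0.01 log units; within the scatter). Compound 4 is therefore estimated at 3500 nM in this assay, with a range of 1500 nM to 8500 nM.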

Compound 4, concentration for 50% growth inhibition: 4430 nM
Compound 4: middle estimate off by 1.3-fold (0.10 log units), on the low side; the range from low to high includes it.
By their numbers in this assay, from the lowest: compounds 3, 2, 1 and 4 (each within the scatter of the next).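

Going by these compounds alone, this is the first single-place step: in this assay, hydrogen in place of methoxy on an aromatic carbon, ortho to a large group, gives a 1.2-fold higher number from compound 1 to compound 4 (0.09 log units; within the scatter), so no weight on this read-out can be assigned to the methoxy at this place. Losing the methoxy, with its 2 heavy atoms and 1 hydrogen-bond acceptor, leaves the number of compound 4 within the scatter of that of compound 1. No measurement offered here speaks to the reason for this result.

From the compounds shown here alone, whether an amine, a carboxylic acid or a chlorine at this place would shift the number beyond the scatter remains open. Also open, going by these compounds, is whether the same exchange of methoxy for hydrogen would give a similar step on the longer chain of compound 2.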